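Aryl replacement in a dihydropyridine-type series: compound 3 to compound 4

The compounds below may be only part of what the source reports. "The series", "measured", "known", "first", "only" and "open" are said of these compounds alone.

Of the compounds shown here, three of the shared core have numbers so far in a functional assay (muscle tissue) with Cavia porcellus as the target; on this read-out higher numbers stand for an effect only at larger amounts of compound and lower numbers for an effect already at smaller amounts. Compound 1 `COC(=O)C1=C(C)N=C(C)/C(=C(/O)OC)C1c1c(F)cccc1Cl` gives 7.59 nM in this assay. Compound 2 `COC(=O)C1=C(C)N=C(C)/C(=C(\O)OC)C1c1cccc(OC(=O)c2ccccc2)c1` gives 6310 nM. Compound 3 `COC(=O)C1=C(C)N=C(C)/C(=C(\O)OC)C1c1cccc(Cl)c1Cl` gives 19.1 nM, which is the second highest of the three numbers; its nearest neighbour is compound 1, with a lower number beyond the usual scatter, and its furthest is compound 2, with a far higher number. Within the data shown here, no pair of measured compounds differs in only one place, so no measured single step is available.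

Compound 4 `COC(=O)C1=C(C)N=C(C)/C(=C(\O)OC)C1c1cccc(C)c1` has not yet been measured. It differs from compound 3 as follows: 3-methylphenyl in place of 2,3-dichlorophenyl on a saturated ring carbon. The two measured compounds whose aryl group carries halogen, compound 1 and compound 3, give the two low numbers, while compound 2 gives the high one; compound 4 carries a 3-methylphenyl with neither kind of substituent, so the direction of the step is not fixed by the data. A rise in the number is nevertheless expected for compound 4, with a 10-fold higher number from compound 3 to compound 4 (1.02 log units; beyond the scatter) as the estimated step from compound 3 in this assay. Compound 4 is thus expected to give about 200 nM, within a range from 40 nM to 1500 nM.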

Compound 4, half-maximal effective concentration: 110 nM
Compound 4: the middle estimate sits 1.8-fold (0.26 log units) above what was measured; low and high end bracket the measured number.
By their numbers in this assay, from the lowest: compound 1; then compound 3; then compound 4; then compound 2.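

In this assay, 3-methylphenyl in place of 2,3-dichlorophenyl on the saturated ring carbon gives a 5.8-fold higher number from compound 3 to compound 4 (0.76 log units; beyond the scatter), so this position tolerates an aryl group without halogen, at a cost beyond the usual scatter. Methyl in place of benzoyloxy on the aromatic carbon gives a 57-fold lower number from compound 2 to compound 4 (1.76 log units; beyond the scatter), the larger of the two steps and the first single-place comparison to show how strongly the number in this series depends on the substituent on that aromatic carbon. No measurement on hand accounts for either step.

The change from 2,3-dichlorophenyl to 3-methylphenyl alters two things at once, so the compounds shown do not separate the contribution of the chlorines from that of the methyl, and a 3-chlorophenyl or a 2-chlorophenyl group at the same saturated ring carbon would be needed to divide that step. On these data alone, it also stays open where groups of other kinds on the same aromatic carbon, such as a methoxy, a hydroxyl or an amine, would fall in the wide range between benzoyloxy and methyl.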